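Swapping the Silicon-Bound Aryl for a Phenethyl Chain

The compounds below may be only part of what the source reports. "The series", "measured", "known", "first", "only" and "open" are said of these compounds alone.

Measured compounds:
compound 1 `CCN(C/C=C/C#CC(C)(C)C)Cc1cccc(OC[Si](C)(C)c2ccc(F)cc2)c1`, 60 nM
compound 2 `CCN(C/C=C/C#CC(C)(C)C)Cc1cccc(OC[Si](C)(C)c2ccc(OC)cc2)c1`, 870 nM

Both compounds were tested in a functional assay on liver (Sus scrofa) for inhibition of squalene monooxygenase (Homo sapiens), using microsomes; on this read-out higher numbers stand for weaker inhibition and lower numbers for stronger inhibition. Compound 2 gives the higher of the two numbers: the step from the fluoro compound to the methoxy compound is a 15-fold higher number from compound 1 to compound 2 (1.16 log units; beyond the scatter), so compound 2 is the weaker inhibitor of the pair, with compound 1 the nearer and only neighbour.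

Compound 3 `CCN(C/C=C/C#CC(C)(C)C)Cc1cccc(OC[Si](C)(C)CCc2ccccc2)c1` is not yet measured. It differs from compound 2 as follows: phenethyl in place of 4-methoxyphenyl on a silicon. This is a different kind of change from the one measured so far: the step from compound 1 to compound 2 exchanged one substituent on the aromatic ring attached to silicon, whereas here the whole 4-methoxyphenyl is replaced by phenethyl. That step was large, which shows that the group on the silicon matters a great deal, but it gives no direction for the present change. The number for compound 3 is therefore estimated with wide uncertainty, as 200 nM, between 40 nM and 1000 nM, which would mean an expected step of a 4.4-fold lower number from compound 2 to compound 3 (0.64 log units; beyond the scatter).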

Compound 3, half-maximal inhibitory concentration: > 10000 nM
Compound 3: no number, only a limit (the forecaster's own chance of this, stated with the estimate: 5%); middle value at least 50-fold (1.69 log units) from the limit.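

In this assay, the result for compound 3 is a limit of the assay and not a number: the limit of > 10000 nM in this assay, at which 1 of the 3 values shown sits.

Even read as a limit, it gives an at least 11-fold higher number from compound 2 to compound 3 (1.06 log units; beyond the scatter), and against the best compound shown it gives an at least 160-fold higher number from compound 1 to compound 3 (2.22 log units; beyond the scatter). Until now, only the substituent on the aromatic ring attached to silicon had changed, whereas this change keeps a six-membered aromatic ring and the count of 8 heavy atoms yet puts a saturated chain between that ring and the silicon, so matching the ring and the atom count is clearly not enough to keep inhibition in this series.

How much weaker compound 3 really is remains unknown, and the compounds shown cannot separate the effect of the chain from that of losing the methoxy group. On these data alone, it also remains open whether a benzyl group, with a shorter link between silicon and ring, or a plain phenyl group on the silicon would behave like compound 1 or like compound 3.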